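The compounds below may be only part of what the source reports. "The series", "measured", "known", "first", "only" and "open" are said of these compounds alone.

Among the compounds with values here, the three compounds measured so far share one core and differ only in what sits on the six-membered ring of that core. Within the data shown here, compound 1 `ClCc1ccccc1Cn1cnc2c(Cl)nc(Cl)nc21` carries two chloro groups there, compound 2 `ClCc1ccccc1Cn1cnc2c(Cl)ncnc21` carries one, and compound 3 `ClCc1ccccc1Cn1cnc2ncnc(Cl)c21` carries its single chloro group at another ring carbon. In a functional assay on U-251 cells (Homo sapiens) for cytotoxicity, read by sulforhodamine B assay, with a stated time of 48 h (on this read-out lower numbers stand for higher toxicity in this test and higher numbers for lower toxicity in this test), compound 1 gives 4570 nM, compound 2 gives 61700 nM and compound 3 gives 10200 nM. Among the measured compounds shown here, compound 2 therefore shows the highest number of the three, that is, the lowest toxicity in this test, and the only single-point step, from compound 1 to compound 2, was a 14-fold higher number from compound 1 to compound 2 (1.13 log units; beyond the scatter).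

Compound 4 `Nc1nc(Cl)c2ncn(Cc3ccccc3CCl)c2n1` is not yet measured. It differs from compound 2 by amino in place of hydrogen on an aromatic carbon. For the measured compounds named here, no measured step exchanges hydrogen for an amino group, so the step from compound 1 to compound 2 bears on it only loosely, as a sign that the substitution pattern on this ring moves the read-out strongly. For compound 4 a moderate step toward lower numbers is expected, a 2.1-fold lower number from compound 2 to compound 4 (0.31 log units; beyond the scatter), giving an estimated 30000 nM with a range from 8000 nM to 100000 nM.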

Compound 4, concentration lethal to 50% of the cells: 72400 nM
For compound 4 the middle estimate is 2.4-fold (0.38 log units) below the measured one, and the stated range covers the measured number.
By their numbers in this assay, from the lowest: compound 1; then compound 3; then compounds 2 and 4 (each within the scatter of the next).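

On the aromatic carbon between two ring nitrogen atoms, amino in place of hydrogen gives a 1.2-fold higher number from compound 2 to compound 4 (0.07 log units; within the scatter) in this assay so the two groups cannot be told apart at this carbon. Amino in place of chloro on the same carbon gives a 16-fold higher number from compound 1 to compound 4 (1.20 log units; beyond the scatter) and this large step runs the same way as the one seen earlier with hydrogen in place of chloro. Among the three groups seen at this carbon, only chloro goes with the clearly lower number and so with the higher toxicity in this test.

From the compounds shown here alone, whether a bromo group, a methoxy group or a longer amine on this carbon would behave like chloro or like hydrogen stays open. Nothing shown here explains why chloro stands apart at this carbon.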